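The source may report more compounds than this note shows. Statements on the series, on what has been measured and on what is new or still open speak of the compounds shown alone.

Measured compounds in a functional assay on MKN-45 cells (Homo sapiens) for antiproliferative activity, read by MTT assay, with a stated time of 72 h, tested at 10 uM; a higher number here means more inhibition at the concentration tested (going by the name of the read-out), a lower number less inhibition:

compound 1 `O=C(Nc1cc(Oc2ccc(Nc3nccc4[nH]cc(-c5ccc(F)cc5)c(=O)c34)cc2F)ccn1)C1CCC1`: 52.8%
compound 2 `CC(=O)Nc1cc(Oc2ccc(Nc3nccc4[nH]cc(-c5ccc(F)cc5)c(=O)c34)cc2F)ccn1`: 77.1%
compound 3 `CC(O)C(=O)Nc1cc(Oc2ccc(Nc3nccc4[nH]cc(-c5ccc(F)cc5)c(=O)c34)cc2F)ccn1`: 67.3%

All three share one core and differ only in the group on the carbonyl carbon of the amide. Compound 3 stands clearly apart from compound 1, as the step of a number 14.5 percentage points higher from compound 1 to compound 3 (beyond the scatter) shows, while the other step, a number 9.8 percentage points lower from compound 2 to compound 3 (within the scatter), lies within the scatter, so compound 2 and compound 3 cannot be told apart on these numbers.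

Compound 4 `CC(C)C(=O)Nc1cc(Oc2ccc(Nc3nccc4[nH]cc(-c5ccc(F)cc5)c(=O)c34)cc2F)ccn1` is the next member. Its change from compound 3 is methyl in place of hydroxy on a saturated chain carbon bound to a carbonyl carbon and a saturated chain carbon. Among the measured compounds shown here, two measured steps bear on swapping groups at this end of the molecule: a number 24.3 percentage points higher from compound 1 to compound 2 (beyond the scatter) and a number 14.5 percentage points higher from compound 1 to compound 3 (beyond the scatter), both modest. The step closest in kind, a number 9.8 percentage points lower from compound 2 to compound 3 (within the scatter), stayed inside the scatter. The expectation is therefore a small step, if any, for compound 4, with a number 4.3 percentage points lower from compound 3 to compound 4 (within the scatter) and no firm direction. The estimate for compound 4 in this assay is 63%, expected to fall between 45% and 80%.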

Compound 4, a percentage reported as inhibition, at one concentration (the size of the read-out at that concentration, not a potency): 95.4%
Compound 4: middle estimate off by 32.4 percentage points, on the low side, and the stated range ends below it.
By their numbers in this assay, from the lowest: compound 1; then compounds 3 and 2 (each within the scatter of the next); then compound 4.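

In this assay, among the compounds shown here, this end of the molecule proves more sensitive than the earlier compounds showed: methyl in place of hydroxy on this saturated chain carbon, a change of one heavy atom, gives a number 28.1 percentage points higher from compound 3 to compound 4 (beyond the scatter) and lies beyond the scatter. Isopropyl on the carbonyl carbon also separates from methyl, with a number 18.3 percentage points higher from compound 2 to compound 4 (beyond the scatter) and from cyclobutyl, with a number 42.6 percentage points higher from compound 1 to compound 4 (beyond the scatter) as the only large step here, so compound 4 stands highest of the four. Nothing available here accounts for this gain.

Open, going by these compounds, is whether a tert-butyl, a cyclopropyl, a longer chain such as propyl or an amine on the carbonyl carbon would match isopropyl. These readings also come from one concentration, so they do not show how potency compares across the compounds.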